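Methyl for hydrogen on the indoline ring of compound 3

The source may report more compounds than this note shows. Statements on the series, on what has been measured and on what is new or still open speak of the compounds shown alone.

Three compounds are measured in a functional assay on A549 cells (Homo sapiens) for inhibition, read by sulforhodamine B assay, with a stated time of 48 h; on this read-out lower numbers stand for stronger inhibition of growth and higher numbers for weaker inhibition of growth. Among the measured compounds shown here, compound 1 `COC(=O)[C@@]1(C)CCC=C2[C@@H]1CC[C@@H](C)[C@]2(C)Cc1c(C)[nH]c2ccc(Br)cc12` gives 15000 nM and compound 2 `COC(=O)[C@@]1(C)CCC=C2[C@@H]1CC[C@@H](C)[C@]2(C)Cc1c(C)[nH]c2ccc(OC)cc12` gives 16000 nM; the only single-point step, a 1.1-fold higher number from compound 1 to compound 2 (0.03 log units; within the scatter), stays within the scatter. Compound 3 `COC(=O)[C@@]1(C)CC[C@@H]2C3=C1CC[C@@H](C)[C@]3(C)C[C@@H]1c3ccccc3N[C@H]21` gives 39000 nM, the highest of the three numbers, with both other compounds beyond the scatter below it. Compound 4 `COC(=O)[C@@]1(C)CC[C@@H]2C3=C1CC[C@@H](C)[C@]3(C)C[C@@H]1c3cc(C)ccc3N[C@H]21` differs from compound 3 by methyl in place of hydrogen on an aromatic carbon. For the measured compounds named here, no measured step exchanges hydrogen for methyl; the one aromatic substituent swap, a 1.1-fold higher number from compound 1 to compound 2 (0.03 log units; within the scatter), is flat, so no step beyond the scatter is expected in this assay, no change at the digits printed from compound 3 to compound 4 (within the scatter). Compound 4 is estimated at 39000 nM, within 20000 nM to 75000 nM.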

Compound 4, concentration for 50% growth inhibition: 27000 nM
Estimate against measurement, compound 4: 1.4-fold (0.16 log units) above; the range from low to high includes it.
By their numbers in this assay, from the lowest: compounds 1, 2, 4 and 3 (each within the scatter of the next, the first and the last beyond it).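

In this assay, among the compounds shown here, methyl in place of hydrogen on this aromatic carbon gives a 1.4-fold lower number from compound 3 to compound 4 (0.16 log units; within the scatter) on the fused system of five rings, the only reading so far at this position. This carbon therefore takes one added carbon atom without a step beyond the scatter. Nothing available accounts for the size of this step.

The compounds shown leave open whether an amine, a carboxylic acid or a longer chain such as propyl on this carbon would produce a step beyond the scatter. On these data alone, whether the other aromatic carbons of this ring behave alike also remains open.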